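Capping the ring amine of compound 1 in the cell assay

The source may hold more compounds than are shown below. What is called first, only, known or untested is meant among the compounds shown, and "the series" means these compounds.

Going by the values given here, compound 1 `CN1CCN(c2ccc(Nc3ncc4nc(Nc5ccc(F)cc5)n([C@H]5CCCNC5)c4n3)cc2)CC1` gives 38 nM in a functional assay on HCC827 cells (Homo sapiens) for antiproliferative activity, read by MTT assay, with a stated time of 72 h (on this read-out lower numbers stand for stronger inhibition and higher numbers for weaker inhibition), and stands highest of the three numbers measured so far. Compound 2 `CN1CCN(c2ccc(Nc3ncc4nc(Nc5ccc(F)cc5)n([C@H]5CCCN(C(=O)CO)C5)c4n3)cc2)CC1` gives 1.8 nM and compound 3 `CN1CCN(c2ccc(Nc3ncc4nc(Nc5ccccc5)n([C@H]5CCN(S(C)(=O)=O)C5)c4n3)cc2)CC1` gives 17 nM in this assay. Among the compounds with values here, the one single-point step available is a 21-fold lower number from compound 1 to compound 2 (1.32 log units; beyond the scatter), so a substituent on the ring amine nitrogen in place of hydrogen has gone with a large move to a lower number.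

Compound 4 `CN1CCN(c2ccc(Nc3ncc4nc(Nc5ccc(F)cc5)n([C@H]5CCN(S(=O)(=O)C6CC6)C5)c4n3)cc2)CC1` differs from compound 1 by 1-(cyclopropylsulfonyl)pyrrolidin-3-yl in place of piperidin-3-yl on an aromatic nitrogen. This change again replaces the amine hydrogen of compound 1 with a substituent, here a cyclopropylsulfonyl group, while also contracting the six-membered ring to a five-membered one. Within the data shown here, no step between measured compounds isolates the ring contraction; compound 3 carries a sulfonyl on a pyrrolidin-3-yl and a phenylamino rather than (4-fluorophenyl)amino group, and its value shows only that such a sulfonylated five-membered ring is compatible with a number below that of compound 1. The step from compound 1 to compound 2 is therefore the main guide, and a lower number beyond the scatter is expected for compound 4, estimated as a 7.6-fold lower number from compound 1 to compound 4 (0.88 log units; beyond the scatter). The estimate for compound 4 in this assay is 5 nM, with a range from 1.5 nM to 15 nM.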

Compound 4, half-maximal inhibitory concentration: 7.5 nM
For compound 4 the middle estimate is 1.5-fold (0.18 log units) below the measured one; the range from low to high includes it.
By their numbers in this assay, from the lowest: compound 2; then compound 4; then compound 3; then compound 1.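

In this assay, a sulfonyl group on the ring nitrogen also goes with a lower number, with a 5.1-fold lower number from compound 1 to compound 4 (0.70 log units; beyond the scatter), so compound 2 and compound 4 both lie below the unsubstituted piperidin-3-yl of compound 1 although their substituents differ. The two substituted groups are not interchangeable at this position, as a 4.2-fold higher number from compound 2 to compound 4 (0.62 log units; beyond the scatter) shows, but this step changes the ring size and the group on the ring nitrogen together, so neither change can be credited with it alone. Nothing at hand bears on the cause of either step.

The compounds shown do not separate ring contraction from substitution on the ring nitrogen, and a 1-(cyclopropylsulfonyl)piperidin-3-yl or an unsubstituted pyrrolidin-3-yl on the same aromatic nitrogen would give the direct comparisons. Also open, on these data alone, is whether other groups on that ring nitrogen, such as a plain acetyl or a chain ending in a carboxylic acid, would lie below compound 1 as compound 2 and compound 4 do.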